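Series notes: thiophene substituent swap on the shared core

This account rests on a few compounds, and the source may have more. Where it says the series, first, only, none or still open, it means among the compounds named here.

In an assay on isolated protein for inhibition of ubiquitin carboxyl-terminal hydrolase 7 (Homo sapiens), read by fluorescence, with stated times of 30 min and 1 h (on this read-out higher numbers stand for weaker inhibition and lower numbers for stronger inhibition), compound 1 `O=C([C@H]1Cc2cc(Cl)cc(-c3ccnc4cc(C5(O)COC5)sc34)c2O1)N1CCNCC1` gives 73 nM. Within the data shown here, compound 2 `Cc1cc(Cl)cc(-c2ccnc3cc(CN4C(=O)C5CC5C4=O)sc23)c1C[C@@H]1CNCCO1`, a different arrangement of the shared core, gives 0.16 nM in this assay, so compound 1 holds the higher of the two numbers; the two values lie far apart, well beyond the scatter, but no single structural step connects them, and only the two values themselves can be read. Compound 3 `Cc1cc2nccc(-c3cc(Cl)cc4c3O[C@@H](C(=O)N3CCNCC3)C4)c2s1` is not yet measured. It differs from compound 1 in one place: methyl in place of 3-hydroxyoxetan-3-yl on an aromatic carbon. Among the measured compounds shown here, no measured pair isolates this change, so its size is open. Exchanging a larger substituent for a methyl at this position is expected to cost some potency, with a step from compound 1 to compound 3 estimated as a 2.1-fold higher number from compound 1 to compound 3 (0.31 log units; beyond the scatter), weakening but possibly within the scatter. Compound 3 is accordingly expected to give 150 nM in this assay, within a range of 40 nM to 600 nM.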

Compound 3, half-maximal inhibitory concentration: 130 nM
For compound 3 the middle estimate is 1.2-fold (0.06 log units) above the measured one; low and high end bracket the measured number.
By their numbers in this assay, from the lowest: compound 2; then compounds 1 and 3 (each within the scatter of the next).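

In this assay, among these compounds, the swap gives a 1.8-fold higher number from compound 1 to compound 3 (0.25 log units; within the scatter), the first reading of this position next to the ring sulfur. On the core of compound 1, exchanging 3-hydroxyoxetan-3-yl for methyl removes the four-membered ring, the hydrogen-bond donor and both hydrogen-bond acceptors of that substituent, with no shift beyond the scatter, so this pair gives no sign that the substituent's ring or its hydrogen-bonding groups are needed to hold the value. No measurement at hand accounts for this result.

Going by these compounds, whether a primary amine, a carboxylic acid or a longer alkyl chain at this position would move the value beyond the scatter remains open, since only these two groups have been compared here on this core. Among the compounds shown here, the value of compound 2, 0.16 nM, cannot be assigned to any one structural place, as no single step connects it to the other compounds.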